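From Methyl to Isopropyl on Compound 3

The source may hold more compounds than are shown below. What is called first, only, known or untested is meant among the compounds shown, and "the series" means these compounds.

In a functional assay on MCF7 cells (Homo sapiens) for antiproliferative activity, read by MTT assay, with a stated time of 72 h (a higher number here means a weaker inhibitor, a lower number a stronger inhibitor), three compounds have been measured so far
- compound 1 `C/C=C/C(=O)Nc1cccc(Oc2nc(Nc3ccn(C)n3)nc3c2CSCC3)c1` gives 40000 nM.
- compound 2 `C=C(C)C(=O)Nc1cccc(Oc2nc(Nc3ccn(C)n3)nc3c2CSCC3)c1` gives > 50000 nM.
- compound 3 `C/C=C/C(=O)Nc1cccc(Oc2nc(Nc3cccc(OC)c3)nc3c2CSCC3)c1` gives 23400 nM.

Compound 2 has the reading > 50000 nM as a limit and not a number. Among the compounds with values here, compound 3 and compound 1 hold the only two exact numbers, and these lie within the scatter of each other.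

Compound 4 `COc1cccc(Nc2nc3c(c(Oc4cccc(NC(=O)/C=C/C(C)C)c4)n2)CSCC3)c1` carries isopropyl in place of methyl on a double-bonded chain carbon bound to a double-bonded chain carbon, so prop-1-en-1-yl becomes 3-methylbut-1-en-1-yl. Within the data shown here, only one measured step touches this group, with 1-methylethenyl in place of prop-1-en-1-yl: an at least 1.2-fold higher number from compound 1 to compound 2 (0.09 log units; that floor lies within the scatter) is its size. The other step, a 1.7-fold lower number from compound 1 to compound 3 (0.23 log units; within the scatter), concerns a different group. Neither goes beyond the scatter, so no step beyond the scatter is expected in this assay for this change, although a single step is thin support. The expected step is a 1.1-fold lower number from compound 3 to compound 4 (0.03 log units; within the scatter) by this estimate. For compound 4 the estimated value is 22000 nM, with an expected range from 9000 nM to 50000 nM.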

Compound 4, half-maximal inhibitory concentration: 21800 nM
Estimate against measurement, compound 4: 1.0-fold (0.00 log units) above; the measured number falls inside the stated range.
By their numbers in this assay, from the lowest: compounds 4, 3 and 1 (each within the scatter of the next). At a limit, above all of these: compound 2.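

In this assay, replacing methyl with isopropyl on a double-bonded chain carbon bound to a double-bonded chain carbon, which turns prop-1-en-1-yl into 3-methylbut-1-en-1-yl, gives a 1.1-fold lower number from compound 3 to compound 4 (0.03 log units; within the scatter) and so leaves the reading in place. Within the data shown here, the only earlier step at this group ended in a limit for compound 2, which gave a floor alone, whereas this change gives an exact pair of values, showing that the chain end can carry isopropyl with no step beyond the scatter. Nothing measured here gives a cause for this step.

From the compounds shown here alone, whether the same position tolerates a chain end bearing a dimethylamino group or a carboxylic acid remains open. Also open, going by these compounds, is whether isopropyl would behave in the same way with 1-methyl-1H-pyrazol-3-yl on the nitrogen, as in compound 1.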